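A few compounds are considered here, and "the series" means these few. Any claim that something is new, unique, unknown or untested is made for them only; others in the source may bear on it.

Measured so far:
- compound 1 `O=C(Nc1ncccc1N1CCN(C(=O)Cn2cnc3cccnc32)CC1)c1cccc(Cl)c1`: in a functional assay on CHO-K1 cells for antagonist activity at C-X-C chemokine receptor type 3 (Homo sapiens), read by FLIPR, with a stated time of 10 min (on this read-out lower numbers stand for stronger inhibition and higher numbers for weaker inhibition), compound 1 gives 177 nM
- compound 2 `COCCOc1ncc(-c2nc(C(F)(F)F)sc2N2CCN(C(=O)Cn3cnc4cccnc43)[C@H](C)C2)cn1`: in this assay compound 2 gives 4.7 nM
- compound 3 `CCOc1ncc(-c2nc(C(F)(F)F)sc2N2CCN(C(=O)Cn3cnc4ccccc43)[C@H](C)C2)cn1`: in this assay compound 3 gives 2 nM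

Compound 3 has the lowest number of the three. Its nearest neighbour is compound 2, whose number is higher by a margin beyond the scatter; compound 1 lies far above both. Within the data shown here, compound 2 and compound 3 differ in two places at once, so no single step can be read from that pair; it shows only that the shared core of compounds 2 and 3 tolerates variation at the bicyclic group on the acetyl arm and at the alkoxy end without leaving the low range.

Compound 4 `CCOc1ncc(-c2nc(C(F)(F)F)sc2N2CCN(C(=O)Cn3ncc4cccnc43)[C@H](C)C2)cn1` is the next point. The change from compound 3 is a group of 9 heavy atoms (6 carbon, 3 nitrogen; one five-membered aromatic ring with 2 hetero atoms, one six-membered aromatic ring with 1 hetero atom) in place of a group of 9 heavy atoms (7 carbon, 2 nitrogen; one five-membered aromatic ring with 2 hetero atoms, one six-membered aromatic ring of carbon only), on a saturated chain carbon bound to a carbonyl carbon. Among the measured compounds shown here, with no measured step of this kind, the expectation is a small shift at most, if anything toward a slightly higher number, likely within or near the scatter: compound 4 is expected to come out near a 2.0-fold higher number from compound 3 to compound 4 (0.30 log units; within the scatter). The estimate for compound 4 in this assay is 4 nM, with a range from 1.5 nM to 12 nM.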

Compound 4, half-maximal inhibitory concentration: 4.1 nM
Beside the measured number, compound 4's estimate is 1.0-fold (0.01 log units) below it, and the stated range covers the measured number.
By their numbers in this assay, from the lowest: compound 3; then compounds 4 and 2 (each within the scatter of the next); then compound 1.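

In this assay, among these compounds, the first step that can be read at one place replaces 1H-benzimidazol-1-yl, on a saturated chain carbon bound to a carbonyl carbon, with a group whose six-membered aromatic ring carries 1 hetero atom, and it gives a 2.1-fold higher number from compound 3 to compound 4 (0.31 log units; beyond the scatter), a modest rise. This separates the bicyclic group from the alkoxy end, which the pair of compound 2 and compound 3 could not do, and shows that this position accepts this change at a modest cost. No measurement at hand accounts for the size of the step.

Still open, on these data alone, is how this position responds to a group of another kind, such as a monocyclic phenyl ring or a chain ending in an amine or a carboxylic acid. Also open, as far as these compounds go, is whether the same step holds with a different alkoxy end on the shared core.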